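The compounds below may be only part of what the source reports. "The series", "measured", "known", "first", "only" and "open" are said of these compounds alone.

Compound 1 `Oc1cc(C(F)(F)F)ccc1-c1nc(-c2ccccc2O)n(-c2ccccc2C(F)(F)F)n1` and compound 2 `COc1ccccc1-n1nc(-c2ccc(C(F)(F)F)cc2O)nc1-c1ccccc1O` differ in one place: methoxy in place of trifluoromethyl on an aromatic carbon. In a functional assay on PC-12 cells (Rattus norvegicus) for cytotoxicity, read by MTT assay, with stated times of 2 h and 24 h, tested at 5 uM (on this read-out higher numbers stand for a stronger effect at the one concentration tested and lower numbers for a weaker effect), compound 1 gives 80% and compound 2 gives 85.6%, so that a number 5.6 percentage points higher from compound 1 to compound 2 (within the scatter). Compound 3 `Oc1cc(C(F)(F)F)ccc1-c1nc(-c2ccccc2O)n(-c2cccc(C(F)(F)F)c2)n1` has a core that differs from that of compound 1 by 3-(trifluoromethyl)phenyl in place of 2-(trifluoromethyl)phenyl on an aromatic nitrogen; in this assay compound 3 gives 92.2%, and a number 12.2 percentage points higher from compound 1 to compound 3 (beyond the scatter). Compound 4 `COc1cccc(-n2nc(-c3ccc(C(F)(F)F)cc3O)nc2-c2ccccc2O)c1` differs from compound 3 by methoxy in place of trifluoromethyl on an aromatic carbon, the same kind of change as from compound 1 to compound 2, though here the place is meta to a large group rather than ortho to it. Because the earlier step of this kind was a number 5.6 percentage points higher from compound 1 to compound 2 (within the scatter), compound 4 is expected to shift by about a number 1.8 percentage points higher from compound 3 to compound 4 (within the scatter), a step small enough to sit inside the usual scatter. Compound 4 is therefore estimated at 94%, likely between 83% and 100%.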

Compound 4, a percentage reported as activity, at one concentration (the size of the read-out at that concentration, not a potency): 96.8%
Estimate against measurement, compound 4: 2.8 percentage points below; the measured number falls inside the stated range.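

In this assay, the exchange of trifluoromethyl for methoxy reads alike on two cores: the same change on two cores in this assay, a number 5.6 percentage points higher (within the scatter) from compound 1 to compound 2 and a number 4.6 percentage points higher (within the scatter) from compound 3 to compound 4, 1 percentage points apart, within the scatter of two such steps

The new step is a number 4.6 percentage points higher from compound 3 to compound 4 (within the scatter), so this change can be carried between these two cores with little effect on the read-out, but two cores do not establish a rule for the series. Changes to the group on the aromatic nitrogen give larger steps: 3-methoxyphenyl in place of 2-methoxyphenyl gives a number 11.2 percentage points higher from compound 2 to compound 4 (beyond the scatter), and 3-methoxyphenyl in place of 2-(trifluoromethyl)phenyl gives a number 16.8 percentage points higher from compound 1 to compound 4 (beyond the scatter).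

The compounds shown leave open how an amine, a carboxylic acid or a longer chain would behave in place of methoxy. They also leave open whether the same exchange would stay this small on a third core.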